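Replacing the imidazole end of compound 2

The compounds below may be only part of what the source reports. "The series", "measured", "known", "first", "only" and "open" are said of these compounds alone.

Measured in a functional assay on the whole organism for antagonist activity, with Mus musculus as the target; on this read-out higher numbers stand for an effect only at larger amounts of compound and lower numbers for an effect already at smaller amounts:
- Compound 1 `CC1CCC(=O)N1CC#CCn1ccnc1`: 20.9 mg/kg
- Compound 2 `O=C1NCCN1CC#CCn1ccnc1`: > 100 mg/kg
- Compound 3 `Cc1cncn1CC#CCN1CCNC1=O`: > 100 mg/kg

Only compound 1 has a true number here. Compound 2 gives only a limit, > 100 mg/kg, and not a measured dose. Compound 3 also gives only a limit, > 100 mg/kg. Compound 2 therefore stands at the limit of > 100 mg/kg in this assay, at which 2 of the 3 values shown sit.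

Compound 4 `CN(C)CC#CCN1CCNC1=O` has not yet been measured. It differs from compound 2 by one change, dimethylamino in place of 1H-imidazol-1-yl on a saturated chain carbon bound to a triple-bonded carbon.

For the measured compounds named here, one measured step bears on this end of the molecule: a step that the two limits leave unreadable from compound 2 to compound 3. That step replaces hydrogen with methyl on an aromatic carbon, and it supplies no size to carry over. The new change also removes the aromatic ring altogether, so the data give no direction for it in this assay. With compound 2 resting on (the limit of > 100 mg/kg in this assay, at which 2 of the 3 values shown sit), the safest expectation is that compound 4 stays near that limit, and it may well report only a limit too. The expected change is a number no higher from compound 2 to compound 4 (the limit leaves the size open). For compound 4 the estimated value is 100 mg/kg, with an expected range from 30 mg/kg to 300 mg/kg.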

Compound 4, dose for half-maximal effect: > 100 mg/kg
Compound 4 ended at the assay's limit; the forecaster's own chance of this, stated with the estimate: 60%; the middle value sits exactly at the limit.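

In this assay compound 4 gives > 100 mg/kg, which is a limit and not a measured dose. Compound 2 gives > 100 mg/kg, also a limit, so no step from it to compound 4 can be read: the limit of > 100 mg/kg in this assay, at which 3 of the 4 values shown sit.

Still open, as far as these compounds go, is how far the true doses of compound 2 and compound 4 lie beyond that limit, and whether dimethylamino in place of 1H-imidazol-1-yl shifts the dose in either direction.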